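The source may hold more compounds than are shown below. What is called first, only, known or untested is meant among the compounds shown, and "the series" means these compounds.

Measured so far:
compound 1 `CN(C)CCn1cnnc1-c1cc(Oc2ccc(NC(=O)N/N=C/c3c[nH]c4ccccc34)cc2F)ccn1`, 790 nM
compound 2 `COc1ccc(/C=N/NC(=O)Nc2ccc(Oc3ccnc(-c4nncn4CCN(C)C)c3)c(F)c2)c(OC)c1`, 1680 nM
compound 3 `CN(C)CCn1cnnc1-c1cc(Oc2ccc(NC(=O)N/N=C/c3cccc(Br)c3)cc2F)ccn1`, 450 nM

All three were tested in a functional assay on MKN-45 cells (Homo sapiens) for cytotoxicity, read by MTT assay, with a stated time of 72 h; on this read-out lower numbers stand for stronger inhibition and higher numbers for weaker inhibition. Compound 3 gives the lowest of the three numbers, but the gap a 1.8-fold lower number from compound 1 to compound 3 (0.24 log units; within the scatter) lies within the scatter; only a 3.7-fold lower number from compound 2 to compound 3 (0.57 log units; beyond the scatter) is clearly beyond it, as is a 2.1-fold higher number from compound 1 to compound 2 (0.33 log units; beyond the scatter). Compound 4 `CN(C)CCn1cnnc1-c1cc(Oc2ccc(NC(=O)N/N=C/c3ccc(F)cc3Cl)cc2F)ccn1` has not yet been measured; it differs from compound 3 by 2-chloro-4-fluorophenyl in place of 3-bromophenyl on a carbon with a double bond to nitrogen. Every measured step swaps the ring at this same place, so all three bear on the question, yet none involves the new ring, and the nearest comparison remains compound 3 itself with 450 nM. For compound 4 a step of a 1.1-fold higher number from compound 3 to compound 4 (0.05 log units; within the scatter) is therefore expected, within the scatter. Compound 4 is estimated at 500 nM, with a range from 200 nM to 1300 nM.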

Compound 4, half-maximal inhibitory concentration: 870 nM
Beside the measured number, compound 4's estimate is 1.7-fold (0.24 log units) below it; measured number inside the range.
By their numbers in this assay, from the lowest: compounds 3, 1, 4 and 2 (each within the scatter of the next, the first and the last beyond it).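

In this assay, a ring with two halogens, 2-chloro-4-fluorophenyl, joins the series on the carbon with a double bond to nitrogen, and a 1.9-fold higher number from compound 3 to compound 4 (0.29 log units; within the scatter) and a 1.9-fold lower number from compound 2 to compound 4 (0.29 log units; within the scatter) and a 1.1-fold higher number from compound 1 to compound 4 (0.04 log units; within the scatter) all lie within the scatter. Compound 4 therefore cannot be told apart from any of the other three, although compound 2 and compound 3 can be told apart from each other. Nothing available explains these numbers. Still open, as far as these compounds go, is whether a phenyl ring carrying an amine or a carboxylic acid here would stand clearly apart, and whether chlorine alone or fluorine alone would give a similar number.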